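The source may hold more compounds than are shown below. What is called first, only, known or untested is meant among the compounds shown, and "the series" means these compounds.

Measured so far:
Compound 1 `Nc1ccc(NC(=O)c2cn(Cc3c(F)cccc3F)c3ccc(=O)[nH]c3c2=O)cc1`: 104 nM
Compound 2 `N#Cc1cccc(NC(=O)c2cn(Cc3c(F)cccc3F)c3ccc(=O)[nH]c3c2=O)c1`: 1070 nM

Both numbers come from an in vitro assay on Sf21 cells for inhibition of high affinity 3',5'-cyclic-AMP phosphodiesterase 7A (Homo sapiens), read by scintillation proximity assay, with a stated time of 30 min; on this read-out lower numbers stand for stronger inhibition and higher numbers for weaker inhibition. Among the compounds with values here, compound 2 stands at the weaker end of these two: in this assay compound 2 gives 1070 nM, and the only measured step, a 10-fold higher number from compound 1 to compound 2 (1.01 log units; beyond the scatter), shows that swapping the group on the amide-type nitrogen can move the number a long way.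

Compound 3 `O=C(Nc1c(F)cccc1F)c1cn(Cc2c(F)cccc2F)c2ccc(=O)[nH]c2c1=O` is not yet measured. It differs from compound 2 by 2,6-difluorophenyl in place of 3-cyanophenyl on an amide-type nitrogen. Within the data shown here, no measured step covers this particular exchange; the one step in hand only shows that the amide substituent matters. Without a closer precedent, the number for compound 3 is estimated to lie somewhat below that of compound 2, with wide uncertainty, so the expected step is a 3.1-fold lower number from compound 2 to compound 3 (0.49 log units; beyond the scatter). For compound 3 the estimate in this assay is 350 nM, within a range of 60 nM to 2000 nM.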

Compound 3, half-maximal inhibitory concentration: > 1000 nM
Compound 3: only a limit was reported; the forecaster's own chance of this, stated with the estimate: 3%; at least 2.8-fold (0.45 log units) between middle value and limit.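

In this assay compound 3 is reported only as a limit, not as a number: the limit of > 1000 nM in this assay, at which 1 of the 3 values shown sits.

The step from compound 2 to compound 3 therefore cannot be read, and the 2,6-difluorophenyl and 3-cyanophenyl groups cannot be ranked against each other. The comparison with the 4-aminophenyl group can be read, and it shows an at least 9.6-fold higher number from compound 1 to compound 3 (0.98 log units; beyond the scatter), so a second replacement on the amide-type nitrogen also lands well on the weaker side of compound 1.

From the compounds shown here alone, it remains open how far past its limit compound 3 actually lies. Also open, going by these compounds, is whether the lower number of compound 1 depends on having an amine at all or on where that amine sits, a question that a plain phenyl group and a 3-aminophenyl group on the same nitrogen could help separate.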